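Chloro for methoxy on the quinolin-3-yl compound

A few compounds are considered here, and "the series" means these few. Any claim that something is new, unique, unknown or untested is made for them only; others in the source may bear on it.

In a functional assay on DU-145 cells (Homo sapiens) for cytotoxicity, read by MTT assay, with a stated time of 48 h (on this read-out higher numbers stand for weaker inhibition and lower numbers for stronger inhibition), compound 1 `COc1ccc(-c2nc3ccccn3c2C(=O)/C=C\Nc2ccc3[nH]ccc3c2)cc1` gives 11300 nM and compound 3 `O=C(/C=C\Nc1ccc2[nH]ccc2c1)c1c(-c2ccc(Cl)cc2)nc2ccccn12` gives 1290 nM on this read-out, while compound 2 `COc1ccc(-c2nc3ccccn3c2C(=O)/C=C\Nc2cnc3ccccc3c2)cc1` stands between them at 5280 nM in the same test. Compound 4 `O=C(/C=C\Nc1cnc2ccccc2c1)c1c(-c2ccc(Cl)cc2)nc2ccccn12` departs from compound 2 by the change chloro in place of methoxy on an aromatic carbon on an aromatic carbon, para to a large group, with 4-methoxyphenyl becoming 4-chlorophenyl. The same exchange has been measured once, as an 8.8-fold lower number from compound 1 to compound 3 (0.94 log units; beyond the scatter) with 1H-indol-5-yl on the amine nitrogen. Replacing that group with quinolin-3-yl is itself a measured step, a 2.1-fold lower number from compound 1 to compound 2 (0.33 log units; beyond the scatter) in size, so the precedent may not carry over in full. A step in the same direction, somewhat smaller, is therefore expected, namely a 5.9-fold lower number from compound 2 to compound 4 (0.77 log units; beyond the scatter) in this assay as estimated here. For compound 4 the estimated value is 900 nM with an expected range from 300 nM to 2800 nM in this test.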

Compound 4, half-maximal inhibitory concentration: 4170 nM
Compound 4: middle estimate off by 4.6-fold (0.67 log units), on the low side; measured number above the stated range.
By their numbers in this assay, from the lowest: compound 3; then compounds 4 and 2 (each within the scatter of the next); then compound 1.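

The step of a 1.3-fold lower number from compound 2 to compound 4 (0.10 log units; within the scatter) shows that chloro in place of methoxy does not give the same result on every compound, and its size depends on the group on the amine nitrogen: the same change on two cores in this assay, an 8.8-fold lower number (0.94 log units; beyond the scatter) from compound 1 to compound 3 and a 1.3-fold lower number (0.10 log units; within the scatter) from compound 2 to compound 4, 6.9-fold (0.84 log units) apart, beyond the scatter of two such steps The quinolin-3-yl for 1H-indol-5-yl exchange also reverses direction once chloro is present, giving a 3.2-fold higher number from compound 3 to compound 4 (0.51 log units; beyond the scatter), so the two changes do not simply add: the same change on two cores in this assay, a 2.1-fold lower number (0.33 log units; beyond the scatter) from compound 1 to compound 2 and a 3.2-fold higher number (0.51 log units; beyond the scatter) from compound 3 to compound 4, 6.9-fold (0.84 log units) apart, beyond the scatter of two such steps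

The compounds shown leave open how a fluoro or trifluoromethyl group at this place would behave with either group on the amine nitrogen. They also do not tell why the two changes fail to add.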